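Hydroxy step repeated on a second core, antiproliferative series

This account rests on a few compounds, and the source may have more. Where it says the series, first, only, none or still open, it means among the compounds named here.

Measured compounds:
compound 1 `CCOc1ccc2nc(Cl)c(/C=N/NC(=O)c3cc4ccccc4oc3=O)cc2c1` with 29900 nM
compound 2 `CCOc1ccc(NC(=O)c2cc3ccc(O)cc3oc2=O)cc1` with 14300 nM
compound 3 `CCOc1ccc(NC(=O)c2cc3ccccc3oc2=O)cc1` with 13400 nM

In a functional assay on PANC-1 cells (Homo sapiens) for antiproliferative activity, read by fluorescence and resazurin assay, with a stated time of 48 h (a lower number here means a stronger inhibitor, a higher number a weaker inhibitor), compound 3 gives 13400 nM and compound 2 gives 14300 nM. The change between them is hydroxy in place of hydrogen on an aromatic carbon, and the step of a 1.1-fold higher number from compound 3 to compound 2 (0.03 log units; within the scatter) shows that this change left the read-out essentially unmoved. Compound 1 gives 29900 nM, the highest of the three numbers, beyond the scatter from both compound 2 and compound 3. The difference between the core of compound 1 and the core of compound 3 is not broken down here.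

Compound 4 `CCOc1ccc2nc(Cl)c(/C=N/NC(=O)c3cc4ccc(O)cc4oc3=O)cc2c1` has not been measured. It differs from compound 1 by hydroxy in place of hydrogen on an aromatic carbon, the same change as from compound 3 to compound 2, at the same kind of place.

For compound 4 the expected step is a 1.1-fold higher number from compound 1 to compound 4 (0.03 log units; within the scatter), because the matching step a 1.1-fold higher number from compound 3 to compound 2 (0.03 log units; within the scatter) lies within the scatter and there is no further evidence that the new core would respond differently. Compound 4 is therefore estimated at 32000 nM, with a likely range from 15000 nM to 70000 nM.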

Compound 4, half-maximal inhibitory concentration: 129 nM
The estimate for compound 4 lay 250-fold (2.39 log units) above the measured number, and the stated range ends above it.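

In this assay, hydroxy in place of hydrogen on an aromatic carbon gives a 230-fold lower number from compound 1 to compound 4 (2.37 log units; beyond the scatter), and this step does not match the one seen on the other core: the same change on two cores in this assay, a 1.1-fold higher number (0.03 log units; within the scatter) from compound 3 to compound 2 and a 230-fold lower number (2.37 log units; beyond the scatter) from compound 1 to compound 4, 250-fold (2.39 log units) apart, beyond the scatter of two such steps. Across these two pairs, the size of the step depends on the core that carries the change, so a step read on one core is no safe guide to the step on another. This does not show why the two cores respond differently, and two pairs set no rule for any further core in the series.

The compounds shown leave open whether the large step belongs to hydroxy alone or would also appear on the core of compound 1 with another group at the same place, such as methoxy, an amine or fluorine. For the compounds shown here, they also leave open which part of the core of compound 1 the step depends on, since no pair here changes that core in one place.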